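Swapping the terminal heteroaryl ring toward a pyridin-3-yl

The source may report more compounds than this note shows. Statements on the series, on what has been measured and on what is new or still open speak of the compounds shown alone.

Measured compounds and their values:
Compound 1, `CCC(C)(C)Cc1c[nH]c(CCc2ccc(-c3ccncc3)cc2)n1`, gives in a functional assay on HEK293 cells for agonist activity at Bombesin receptor subtype-3 (Homo sapiens), read by luminescence and calcium flux, with a stated time of 10 min (on this read-out higher numbers stand for an effect only at larger amounts of compound and lower numbers for an effect already at smaller amounts), a value of 305 nM.
Compound 2, `CCC(C)(C)Cc1c[nH]c(CCc2ccc(-c3cnccn3)cc2)n1`, gives in this assay a value of 431 nM.
Compound 3, `CCC(C)(C)Cc1c[nH]c(CCc2ccc(-n3cncn3)cc2)n1`, gives in this assay a value of 570 nM.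

All three share the same core and differ only in the small aromatic ring attached to the outer benzene ring. Compound 3 carries the triazole there. Its number sits apart from the others only within the scatter: the step of a 1.3-fold higher number from compound 2 to compound 3 (0.12 log units; within the scatter), and the step of a 1.9-fold higher number from compound 1 to compound 3 (0.27 log units; within the scatter). The step of a 1.4-fold higher number from compound 1 to compound 2 (0.15 log units; within the scatter) is of the same kind. Across these three compounds, then, the choice of ring has not moved the read-out beyond what repeat measurements would show.

Compound 4, `CCC(C)(C)Cc1c[nH]c(CCc2ccc(-c3cccnc3)cc2)n1`, carries a change at that same place: pyridin-3-yl in place of 1H-1,2,4-triazol-1-yl on an aromatic carbon. The nearest measured precedent is the six-membered ring with one nitrogen in compound 1, which gave 305 nM, and the six-membered ring with two nitrogens in compound 2. Since every step among the measured rings stayed within the scatter, no step beyond the scatter is expected for this assay here either. The estimated step of a 1.5-fold lower number from compound 3 to compound 4 (0.18 log units; within the scatter) is expected to be small. Compound 4 is estimated at 380 nM, within a range of 170 nM to 850 nM.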

Compound 4, half-maximal effective concentration: 131 nM
The estimate for compound 4 lay 2.9-fold (0.46 log units) above the measured number, outside the stated range (below it).
By their numbers in this assay, from the lowest: compound 4; then compounds 1, 2 and 3 (each within the scatter of the next).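

In this assay the place on the outer benzene ring turns out to matter after all: pyridin-3-yl in place of 1H-1,2,4-triazol-1-yl gives a 4.4-fold lower number from compound 3 to compound 4 (0.64 log units; beyond the scatter) and pyridin-3-yl in place of pyrazin-2-yl gives a 3.3-fold lower number from compound 2 to compound 4 (0.52 log units; beyond the scatter), so compound 4 has the lowest number of the four. The most informative comparison is with pyridin-4-yl, a ring that differs from pyridin-3-yl only in where its nitrogen sits, yet this swap still gives a 2.3-fold lower number from compound 1 to compound 4 (0.37 log units; beyond the scatter), which shows that on this read-out the location of the ring nitrogen counts, and not only the presence of a small aromatic ring. Nothing available explains why this one ring stands apart from the other three.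

From the compounds shown here alone, whether the trend extends to pyridin-2-yl or a plain phenyl ring, or to a quite different group at this carbon such as an amine or a carboxylic acid, remains open. Also open, going by these compounds, is whether the advantage of pyridin-3-yl would survive a change elsewhere in the shared core, such as a shorter chain.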